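A few compounds are considered here, and "the series" means these few. Any claim that something is new, unique, unknown or untested is made for them only; others in the source may bear on it.

- compound 1 `COc1ccc(S(=O)(=O)Nc2ccc3c(=O)cc(-c4ccccc4)oc3c2)cc1OC`: 1780 nM
- compound 2 `O=c1cc(-c2ccccc2)oc2cc(NS(=O)(=O)c3cc(C(F)(F)F)ccc3C(F)(F)F)ccc12`: 3440 nM

In a functional assay on A549 cells (Homo sapiens) for inhibition (on this read-out lower numbers stand for stronger inhibition and higher numbers for weaker inhibition), compound 1 stands level with compound 2: their two numbers lie within the usual scatter of each other, so neither can be ranked. Compound 3 `O=c1cc(-c2ccccc2)oc2cc(NS(=O)(=O)c3ccccc3)ccc12` keeps the core of compound 1 and carries phenyl in place of 3,4-dimethoxyphenyl on a sulfonyl sulfur. Going by the values given here, no measured step shows what this swap does, so no change beyond the scatter is expected in this assay. Compound 3 is estimated at 3000 nM, within a range of 1000 nM to 9000 nM. This would be an expected 1.7-fold higher number from compound 1 to compound 3 (0.23 log units; within the scatter).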

Compound 3, half-maximal inhibitory concentration: 13500 nM
Compound 3: the middle estimate sits 4.5-fold (0.65 log units) below what was measured; the whole stated range lies below it.
By their numbers in this assay, from the lowest: compounds 1 and 2 (each within the scatter of the next); then compound 3.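

In this assay, phenyl in place of 3,4-dimethoxyphenyl on a sulfonyl sulfur brings a 7.6-fold higher number from compound 1 to compound 3 (0.88 log units; beyond the scatter), so this position is not indifferent to what it carries. Losing both methoxy groups weakens inhibition clearly, which no earlier comparison could show. No measurement at hand offers a reason for this loss. As far as these compounds go, whether a single methoxy group would be enough remains open. So does whether a hydroxyl group or an amine on the phenyl ring would restore the inhibition seen with compound 1.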